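A few compounds are considered here, and "the series" means these few. Any claim that something is new, unique, unknown or untested is made for them only; others in the source may bear on it.

Working notes on the series.

Compound 1 `C=C(CC)C(=O)c1ccc(OCC(=O)Nc2ccc(C(=O)O)c(O)c2)c(Cl)c1Cl` and compound 2 `C=C(CC)C(=O)c1ccc(OCC(=O)Nc2ccc(C(=O)OC)cc2)c(Cl)c1Cl` share a core and differ in the substitution of the anilide ring. In a functional assay on CLL cells (Homo sapiens) for cytotoxicity, read by MTT assay, with a stated time of 48 h (a lower number here means that less compound is needed, a higher number that more compound is needed for the effect), compound 2 gives 4100 nM. Compound 1 in this assay reaches only a limit of the assay, > 25000 nM. For the measured compounds named here, compound 2 therefore stands as the only compound of the pair with a measured number; the other value is a limit, as noted in the limit of > 25000 nM in this assay, at which 1 of the 2 values shown sits.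

Compound 3 `C=C(CC)C(=O)c1ccc(OCC(=O)Nc2ccc(CC(=O)O)cc2)c(Cl)c1Cl` has not yet been measured in this assay. It differs from compound 2 as follows: carboxymethyl in place of methoxycarbonyl on an aromatic carbon. Going by the values given here, the free acid in compound 3 resembles the acid of compound 1, which sat at the limit, but no step between compound 1 and compound 2 is available to quantify the role of that group alone, since the two also differ elsewhere on the ring.

The step from compound 2 to compound 3 is expected to weaken potency beyond the scatter, a 3.7-fold higher number from compound 2 to compound 3 (0.56 log units; beyond the scatter), on the pointer given by compound 1 at its limit > 25000 nM. Compound 3 is estimated at 15000 nM, with a range from 4000 nM to 60000 nM, and a real chance that only a limit is reported.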

Compound 3, half-maximal effective concentration: 3200 nM
For compound 3 the middle estimate is 4.7-fold (0.67 log units) above the measured one; the whole stated range lies above it.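

The change at this aromatic carbon, para to a large group, gives in this assay a 1.3-fold lower number from compound 2 to compound 3 (0.11 log units; within the scatter), so carboxymethyl and methoxycarbonyl cannot be told apart at this position in this read-out. The pair shows that a group with a hydrogen-bond donor can replace one without such a donor here and leave the number within the scatter, and that a free acid on this position does not by itself go with a value at the limit, as compound 3 shows. Compound 1 remains a limit of the assay and not a number: the limit of > 25000 nM in this assay, at which 1 of the 3 values shown sits.

For the compounds shown here, no single-place step links compound 1 to compound 2 or compound 3, so the ring hydroxyl and the acid group of compound 1 remain unseparated in their bearing on its limit. Also open, on these data alone, is how this position responds to a longer chain ending in a carboxylic acid, to a primary amide or to an aminomethyl group, and whether any of these moves the number beyond the scatter.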